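Working notes: from compound 2 to compound 3

This account rests on a few compounds, and the source may have more. Where it says the series, first, only, none or still open, it means among the compounds named here.

- Compound 1 (`O=c1cc(-c2ccccc2)oc2cc(OCCCCNc3nc4ccc([N+](=O)[O-])cc4s3)cc(O)c12`) : 13.2 ug/mL
- Compound 2 (`O=c1cc(-c2ccccc2)oc2cc(OCCCCNc3nc4ccc(Br)cc4s3)cc(O)c12`) : 12.4 ug/mL
- Compound 3 (`O=c1cc(-c2ccccc2)oc2cc(OCCCCNNc3nc4ccccc4s3)cc(O)c12`) : not yet measured

Both values come from a functional assay on Ca-Ski cells (Homo sapiens) for cytotoxicity, read by sulforhodamine B assay, with a stated time of 48 h; on this read-out higher numbers stand for weaker inhibition and lower numbers for stronger inhibition. Compound 2 stands level with compound 1 on these numbers, and the two cannot be ranked. The step between them is a 1.1-fold lower number from compound 1 to compound 2 (0.03 log units; within the scatter), which is bromo in place of nitro on an aromatic carbon.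

The next change is (1,3-benzothiazol-2-yl)amino in place of 6-bromo-1,3-benzothiazol-2-yl on an amine nitrogen. In words, this is (1,3-benzothiazol-2-yl)amino in place of 6-bromo-1,3-benzothiazol-2-yl on an amine nitrogen.

Within the data shown here, that single measured step is the only evidence that bears on this change, and it bears only in part. Among the measured compounds shown here, no measured compound carries the (1,3-benzothiazol-2-yl)amino group, and none lacks a group on the aromatic carbon. With so little to go on, no direction can be argued in this assay, and no shift beyond the scatter is expected, although the range is kept wide.

The expected step is a 1.0-fold lower number from compound 2 to compound 3 (0.01 log units; within the scatter).

For compound 3 the estimated value is 12 ug/mL, with an expected range from 5 ug/mL to 27 ug/mL.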

Compound 3, half-maximal inhibitory concentration: 14.6 ug/mL
Compound 3: the middle estimate sits 1.2-fold (0.09 log units) below what was measured; the range from low to high includes it.
By their numbers in this assay, from the lowest: compounds 2, 1 and 3 (each within the scatter of the next).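

In this assay, moving to (1,3-benzothiazol-2-yl)amino on the amine nitrogen gives a 1.2-fold higher number from compound 2 to compound 3 (0.07 log units; within the scatter), and the same change read against the nitro member gives a 1.1-fold higher number from compound 1 to compound 3 (0.04 log units; within the scatter). The earlier pair showed only that bromo and nitro on an aromatic carbon could not be told apart; now a change that removes the aromatic substituent and also adds a nitrogen to the link to the chain leaves the number level as well, so compounds 1, 2 and 3 cannot be ranked. The data at hand offer no measurement that would account for this flat result.

Open, on these data alone, is whether the two parts of this change each leave the number level when taken alone, since the loss of the bromo and the added nitrogen arrive together: the plain 1,3-benzothiazol-2-yl group on the amine nitrogen would separate them. Also open, as far as these compounds go, is whether any step beyond the scatter can be found at all, for instance with a carboxylic acid or an amine on the aromatic carbon, or with a longer chain.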